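This account rests on a few compounds, and the source may have more. Where it says the series, first, only, none or still open, it means among the compounds named here.

In a functional assay on HeLa cells (Homo sapiens) for antiproliferative activity, read by sulforhodamine B assay, with a stated time of 48 h (on this read-out higher numbers stand for weaker inhibition and lower numbers for stronger inhibition), two compounds have been measured so far: compound 1 `COc1cc(C(=O)/C=C\Nc2ccc(-c3nc4cc(OC)c(OC)c(OC)c4s3)cc2C)cc([N+](=O)[O-])c1OC` gives 13100 nM and compound 2 `COc1ccc(C(=O)/C=C\Nc2ccc(-c3nc4cc(OC)c(OC)c(OC)c4s3)cc2C)cc1F` gives 1200 nM. Compound 2 therefore holds the lower number of the two, with a gap beyond the scatter. Compound 3 `COc1ccc(C(=O)/C=C\Nc2ccc(-c3nc4cc(OC)c(OC)c(OC)c4s3)cc2C)cc1[N+](=O)[O-]` differs from compound 2 by nitro in place of fluoro on an aromatic carbon, with nitro in place of fluoro on an aromatic carbon, ortho to a methoxy group. For the measured compounds named here, no measured step covers this change, but compound 1, which also carries a nitro group, gives 13100 nM. A moderate move toward weaker inhibition in this assay is therefore expected, with an estimated size of a 2.5-fold higher number from compound 2 to compound 3 (0.40 log units; beyond the scatter). The estimate for compound 3 is 3000 nM, within a range of 800 nM to 12000 nM.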

Compound 3, half-maximal inhibitory concentration: 13400 nM
Compound 3: the middle estimate sits 4.5-fold (0.65 log units) below what was measured, outside the stated range (above it).
By their numbers in this assay, from the lowest: compound 2; then compounds 1 and 3 (each within the scatter of the next).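

In this assay, nitro in place of fluoro on the aromatic carbon ortho to a methoxy group gives an 11-fold higher number from compound 2 to compound 3 (1.05 log units; beyond the scatter) at this position, so the position is sensitive to this change. With nitro held in place, hydrogen in place of methoxy gives a 1.0-fold higher number from compound 1 to compound 3 (0.01 log units; within the scatter) and so leaves the value unmoved in this pair. No evidence is available that accounts for the large step. From the compounds shown here alone, whether an amine or a carboxylic acid at this position would match nitro or fluoro remains open, as does the value with hydrogen there.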